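This account rests on a few compounds, and the source may have more. Where it says the series, first, only, none or still open, it means among the compounds named here.

Compound 1, `Cc1ccc(NC(=O)c2c(O)c3cccnc3n(-c3ccccc3)c2=O)cc1`: -3.5%
Compound 2, `COc1ccc(NC(=O)c2c(O)c3cccnc3n(-c3ccccc3)c2=O)cc1`: 0.3%
Compound 3, `O=C(Nc1ccc([N+](=O)[O-])cc1)c1c(O)c2cccnc2n(-c2ccccc2)c1=O`: -7.6%

In a functional assay on the whole organism for inhibition, with Rattus norvegicus as the target, read by paw edema, at a dose of 100 mg/kg by the oral route (on this read-out lower numbers stand for less inhibition and higher numbers for more inhibition at the one dose given (going by the name of the read-out)), compound 3 gives -7.6%, the lowest of the three numbers, yet the step of a number 4.1 percentage points lower from compound 1 to compound 3 (within the scatter) and the step of a number 7.9 percentage points lower from compound 2 to compound 3 (within the scatter) both lie within the scatter, so nothing separates the three measured compounds on this read-out. Going by the values given here, the one remaining measured step, a number 3.8 percentage points higher from compound 1 to compound 2 (within the scatter), is likewise within the scatter.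

Compound 4, `O=C(Nc1nccs1)c1c(O)c2cccnc2n(-c2ccccc2)c1=O`, is reached from compound 3 by a change at a different position: 1,3-thiazol-2-yl in place of 4-nitrophenyl on an amide-type nitrogen. The three measured steps all concern a substituent on an aromatic carbon, not the group on the amide-type nitrogen, so none of them speaks directly to this change. Among the compounds with values here, what they do show is that the whole series so far sits close to no inhibition, and there is no measured step that would point in either direction. The expected step of a number 7.6 percentage points higher from compound 3 to compound 4 (within the scatter) is therefore none beyond the scatter. Compound 4 is estimated to give 0% in this assay, expected to fall between -12% and 12%.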

Compound 4, a percentage reported as inhibition, in the whole organism at one dose (the size of the read-out at that dose, not a potency): 4.6%
Estimate against measurement, compound 4: 4.6 percentage points below, within the range that was stated.
By their numbers in this assay, from the lowest: compounds 3, 1, 2 and 4 (each within the scatter of the next, the first and the last beyond it).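

In this assay, going by these compounds alone, the change on the amide-type nitrogen gives the only step that lies beyond the scatter, a number 12.2 percentage points higher from compound 3 to compound 4 (beyond the scatter), so 1,3-thiazol-2-yl in place of 4-nitrophenyl can move the read-out, though only modestly. The same comparison does not hold against the other two groups: with 4-methoxyphenyl the step is a number 4.3 percentage points higher from compound 2 to compound 4 (within the scatter), and with 4-methylphenyl it is a number 8.1 percentage points higher from compound 1 to compound 4 (within the scatter), so the separation rests on compound 3 alone. No measurement shown here offers an explanation for this step.

The compounds shown leave open whether a pyridin-2-yl ring or a butyl chain on the amide-type nitrogen would read differently from 1,3-thiazol-2-yl. They also leave open what an amine or a carboxylic acid would do in place of the methyl, methoxy or nitro group on the phenyl ring.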